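Aryl amine series: methyl to iodo exchange

A few compounds are considered here, and "the series" means these few. Any claim that something is new, unique, unknown or untested is made for them only; others in the source may bear on it.

Compound 1 `O=C(C1=C(O)C(=O)N(CCCn2ccnc2)C1c1ccc(Br)cc1)c1ccccc1` gives "not active" (no number reported) in a functional assay on U2OS cells (Homo sapiens) for antiproliferative activity, read by MTT assay, with a stated time of 72 h; a higher number here means a weaker inhibitor, a lower number a stronger inhibitor. Compound 2 `NC1=C(C(=O)c2ccccc2)C(c2ccc(Br)cc2)N(CCCn2ccnc2)C1=O` gives 149000 nM in this assay. Compound 3 `Cc1ccc(NC2=C(C(=O)c3ccccc3)C(c3ccc(Br)cc3)N(CCCn3ccnc3)C2=O)cc1` gives 24100 nM in this assay, the lowest of the two numbers reported, reached through a 6.2-fold lower number from compound 2 to compound 3 (0.79 log units; beyond the scatter). Compound 4 `O=C(C1=C(Nc2ccc(I)cc2)C(=O)N(CCCn2ccnc2)C1c1ccc(Br)cc1)c1ccccc1` is not yet measured. It differs from compound 3 by iodo in place of methyl on an aromatic carbon. Going by the values given here, no measured step changes a substituent on this aromatic ring; the one step in hand, a 6.2-fold lower number from compound 2 to compound 3 (0.79 log units; beyond the scatter), concerns the presence of the whole 4-methylphenyl group on the amine nitrogen and says nothing about exchanging one group for another on it. Within the scatter, the expected step is a 1.1-fold lower number from compound 3 to compound 4 (0.04 log units; within the scatter). Compound 4 is estimated at 22000 nM in this assay, with a range of 7000 nM to 70000 nM.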

Compound 4, half-maximal inhibitory concentration: 12000 nM
Compound 4: the middle estimate sits 1.8-fold (0.26 log units) above what was measured; the measured number falls inside the stated range.
By their numbers in this assay, from the lowest: compounds 4 and 3 (each within the scatter of the next); then compound 2.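

In this assay the exchange on this aromatic carbon gives a 2.0-fold lower number from compound 3 to compound 4 (0.30 log units; within the scatter), so methyl and iodo cannot be told apart here. The aryl group on the amine nitrogen keeps its effect with iodo in place of methyl, with a 12-fold lower number from compound 2 to compound 4 (1.09 log units; beyond the scatter) against the hydrogen. Nothing measured accounts for either step.

Open, going by these compounds, is whether a methoxy group, an amine or a carboxylic acid on this carbon would separate from methyl and iodo. Also open, on these data alone, is whether any of these groups behaves the same elsewhere on the ring.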